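The source may hold more compounds than are shown below. What is called first, only, known or untested is meant among the compounds shown, and "the series" means these compounds.

Compound 1 `COc1cccc(/C=C/C(=O)c2c(OC)cc(OC)cc2OC)c1` and compound 2 `COc1cc(OC)c(C(=O)/C=C/c2ccccc2)c(OC)c1` share the same core and were both tested in a functional assay on Caco-2 cells (Homo sapiens), read by fluorescence and BrdU incorporation, with a stated time of 48 h, tested at 25 uM (a lower number here means a stronger effect, a higher number a weaker effect of the compound at the concentration tested), where compound 1 gives 6% and compound 2 gives 24%. Compound 1 thus has the lower of the two numbers, the stronger effect of the pair. Within the data shown here, the only measured step, a number 18 percentage points higher from compound 1 to compound 2 (beyond the scatter), came from hydrogen in place of methoxy on an aromatic carbon. Compound 3 `COc1cccc(/C=C/C(=O)c2c(O)cc(OC)cc2OC)c1` differs from compound 1 in another place: hydrogen in place of methyl on an oxygen on an aromatic ring. Among the measured compounds shown here, no measured step touches this oxygen, so the step from compound 1 to compound 2 serves only as a rough guide to how much a small change at a methoxy group can move the number. A modest rise is therefore expected, a number 14 percentage points higher from compound 1 to compound 3 (beyond the scatter), of roughly the size seen before. For compound 3 the estimate in this assay is 20%, with a likely range from 3% to 45%.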

Compound 3, a percentage reported as activity, at one concentration (the size of the read-out at that concentration, not a potency): 34%
For compound 3 the middle estimate is 14 percentage points below the measured one; the range from low to high includes it.
By their numbers in this assay, from the lowest: compound 1; then compounds 2 and 3 (each within the scatter of the next).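

The methoxy to hydroxy change on this oxygen gives a number 28 percentage points higher from compound 1 to compound 3 (beyond the scatter) in this assay, so the effect at this position is sensitive to the loss of a single methyl group. Together with a number 18 percentage points higher from compound 1 to compound 2 (beyond the scatter), this makes two separate places on the core of compound 1 where a one-place change weakens the effect, although only these two changes are shown. Nothing available explains why removing this methyl group raises the number.

The compounds shown leave open whether a longer chain on this oxygen, such as an ethyl or propyl group, would leave the number close to that of compound 1 or raise it further. They also leave open what an amine in place of the oxygen on the aromatic ring would do.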